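The source may report more compounds than this note shows. Statements on the series, on what has been measured and on what is new or still open speak of the compounds shown alone.

Measured so far in an ADME assay on H9c2 cells (Rattus norvegicus) for cytotoxicity, read by resazurin assay, with a stated time of 72 h; a lower number here means that less compound is tolerated, a higher number that more compound is tolerated:
compound 1 `C/C(=N\Nc1nc(-c2ccccc2)c(C)s1)c1ccc(Cl)c(Cl)c1`, > 50000 nM
compound 2 `C/C(=N\N=c1\scc(-c2ccccc2)n1-c1ccccc1)c1ccc(Cl)c(Cl)c1`, > 50000 nM
compound 3 `C/C(=N\Nc1nc(-c2ccccn2)cs1)c1ccc(Cl)c(Cl)c1`, 10200 nM

The value of compound 1 is a limit of this assay, not a number. The value of compound 2 is likewise a limit. Compound 3 is the only one of the three that gives a number in this assay; the other two sit at the limit, as the limit of > 50000 nM in this assay, at which 2 of the 3 values shown sit, states. Among the compounds with values here, no step between measured compounds that differ in one place is available, so the tolerance of compound 4 `COc1ccc(-c2csc(N/N=C(\C)c3ccc(Cl)c(Cl)c3)n2)cc1` cannot be read from a measured step. Compound 4 differs from compound 3 by 4-methoxyphenyl in place of pyridin-2-yl on an aromatic carbon. With two of three values at the limit, compound 4 is expected to be tolerated at least as well as compound 3. The expected step of a 2.9-fold higher number from compound 3 to compound 4 (0.47 log units; beyond the scatter) points toward more compound tolerated, with a fair chance that only a limit is returned. Compound 4 is estimated at 30000 nM, within 8000 nM to 50000 nM.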

Compound 4, half-maximal cytotoxic concentration: > 50000 nM
Compound 4: only a limit was reported; the forecaster's own chance of this, stated with the estimate: 45%; middle value at least 1.6-fold (0.22 log units) away from the limit.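

In this assay, 4-methoxyphenyl in place of pyridin-2-yl on the aromatic carbon next to the ring nitrogen gives an at least 4.9-fold higher number from compound 3 to compound 4 (0.69 log units; beyond the scatter), the only one-place step shown. The size of this step is open upward, since compound 4 returns only a limit, and compound 3 remains the only compound with a number: the limit of > 50000 nM in this assay, at which 3 of the 4 values shown sit.

Open, from the compounds shown here alone, is whether the lower number belongs to pyridin-2-yl alone or also comes with other groups on this carbon, such as pyridin-4-yl, an amine or a carboxylic acid.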